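Anilino substitution in the sulfonylquinoxaline series

This account rests on a few compounds, and the source may have more. Where it says the series, first, only, none or still open, it means among the compounds named here.

Measured compounds:
compound 1 `O=S(=O)(c1ccccc1)c1nc2ccccc2nc1Nc1ccccc1` 590 nM
compound 2 `O=S(=O)(c1ccccc1)c1nc2ccccc2nc1Nc1ccc(F)cc1` 14200 nM
compound 3 `Cc1ccc(S(=O)(=O)c2nc3ccccc3nc2Nc2ccccc2)cc1` 1060 nM

In a functional assay on PC-3 cells (Homo sapiens) for cytotoxicity, read by MTT assay, with a stated time of 72 h (a higher number here means a weaker inhibitor, a lower number a stronger inhibitor), compound 3 gives 1060 nM, the second highest number of the three, within the scatter of compound 1 and well apart from compound 2. Compound 4 `Cc1ccc(S(=O)(=O)c2nc3ccccc3nc2Nc2cccc(O)c2)cc1` differs from compound 3 by hydroxy in place of hydrogen on an aromatic carbon. Among the measured compounds shown here, no measured step introduces a hydroxy group. The step of a 1.8-fold higher number from compound 1 to compound 3 (0.25 log units; within the scatter) placed a substituent on the sulfonyl-bound ring and stayed within the scatter. The step of a 24-fold higher number from compound 1 to compound 2 (1.38 log units; beyond the scatter) placed a substituent on the anilino ring, as here, and was large and weakening. Substitution on the anilino ring therefore appears to matter, and a weakening step a 3.3-fold higher number from compound 3 to compound 4 (0.52 log units; beyond the scatter) is expected for compound 4, though smaller, given the uncertainty about hydroxy. Compound 4 is estimated at 3500 nM, range 900 nM to 14000 nM.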

Compound 4, half-maximal inhibitory concentration: 1690 nM
Compound 4: middle estimate off by 2.1-fold (0.32 log units), on the high side, within the range that was stated.
By their numbers in this assay, from the lowest: compounds 1, 3 and 4 (each within the scatter of the next, the first and the last beyond it); then compound 2.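

In this assay the change from phenyl to 3-hydroxyphenyl reads a 1.6-fold higher number from compound 3 to compound 4 (0.20 log units; within the scatter), so a hydroxy group meta to a large group is carried on the anilino ring without a step beyond the scatter. Among the compounds shown here, the only other anilino change, fluoro in place of hydrogen, was large (a 24-fold higher number from compound 1 to compound 2 (1.38 log units; beyond the scatter)), so a substituent on this ring does not by itself give a large step, although the two changes differ in group, place and parent compound. Nothing at hand bears on the reason for this difference.

Open, as far as these compounds go, is whether an amine, a carboxylic acid or a methoxy group at this place reads like hydroxy. Also open, from the compounds shown here alone, is whether hydroxy gives a similar step on the anilino ring of compound 1.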